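A few compounds are considered here, and "the series" means these few. Any claim that something is new, unique, unknown or untested is made for them only; others in the source may bear on it.

Compound 3 `COc1ccc(-c2nn(-c3ccccc3)cc2C(=O)/C=C\Nc2ccc(Cl)cc2)cc1` gives 3890 nM in a functional assay on PC-3 cells (Homo sapiens) for antiproliferative activity, read by MTT assay, with a stated time of 48 h (on this read-out higher numbers stand for weaker inhibition and lower numbers for stronger inhibition), the lower of the two numbers measured, yet within the scatter of compound 2 `COc1ccc(-c2nn(-c3ccccc3)cc2C(=O)/C=C\Nc2ccc(F)cc2)cc1`, which gives 5730 nM; the halogen swap a 1.5-fold lower number from compound 2 to compound 3 (0.17 log units; within the scatter) is not a real change. Compound 1 `O=C(/C=C\Nc1ccc(C(F)(F)F)cc1)c1cn(-c2ccccc2)nc1-c1ccc(Cl)cc1` gives only a limit, > 50000 nM. Compound 4 `COc1ccc(-c2nn(-c3ccccc3)cc2C(=O)/C=C\Nc2ccc(C(F)(F)F)cc2)cc1` differs from compound 3 by trifluoromethyl in place of chloro on an aromatic carbon. For the measured compounds named here, no measured step covers exactly this change; compound 1 carries the same trifluoromethyl group but also another aryl on the core, so its limit of > 50000 nM in this assay, at which 1 of the 3 values shown sits, bears only loosely on the step. On that basis a weaker number is expected for compound 4, estimated at 12000 nM with a range of 3500 nM to 50000 nM. The expected step is a 3.1-fold higher number from compound 3 to compound 4 (0.49 log units; beyond the scatter).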

Compound 4, half-maximal inhibitory concentration: > 50000 nM
Compound 4: no number, only a limit; the forecaster's own chance of this, stated with the estimate: 30%; middle value at least 4.1-fold (0.61 log units) from the limit.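

On this position, para to a large group, the halogens leave the number within the scatter, but the larger trifluoromethyl group does not: it gives an at least 12-fold higher number from compound 3 to compound 4 (1.10 log units; beyond the scatter) and an at least 8.7-fold higher number from compound 2 to compound 4 (0.94 log units; beyond the scatter). On these data alone, compound 4 gives only a limit, so both steps are floors and their true size is unknown. The step between compound 1 and compound 4 cannot be read, as both values are limits: the limit of > 50000 nM in this assay, at which 2 of the 4 values shown sit.

Still open, as far as these compounds go, is whether activity at this place tolerates anything beyond fluoro and chloro, such as a methyl, an amine or a carboxylic acid. Also open, from the compounds shown here alone, is whether replacing methoxy on the other aryl changes the outcome with chloro held constant.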